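Chloro to Fluoro on the Ring Attached to Oxygen

This account rests on a few compounds, and the source may have more. Where it says the series, first, only, none or still open, it means among the compounds named here.

Measured compounds:
Compound 1, `Cn1c(COc2cccc(C(=O)O)c2)nc2ccc(Oc3ncccc3Cl)cc21`, in a physicochemical assay for lipophilicity, read by LC-MS, in phosphate buffer, measured as octanol-water partition, with a stated time of 30 min, at pH 7.4, tested at 200 mM (on this read-out higher numbers stand for higher lipophilicity and lower numbers for lower lipophilicity), gives 1.1.
Compound 2, `Cn1c(COc2cccc(C(=O)O)c2)nc2ccc(Oc3ncccc3F)cc21`, in this assay gives 0.6.
Compound 3, `Cn1c(COc2cccc(C(=O)O)c2)nc2ccc(Oc3ncc(Cl)cc3Cl)cc21`, in this assay gives 1.9.

All three share one core and differ only in the group sitting on an oxygen on an aromatic ring. From compound 1 to compound 2 the change is fluoro in place of chloro on an aromatic carbon, and it produced a number 0.50 log units lower from compound 1 to compound 2 (beyond the scatter). The core of compound 3 differs from that of compound 1 by chloro in place of hydrogen on an aromatic carbon, which produced a number 0.80 log units higher from compound 1 to compound 3 (beyond the scatter). Compound 3 stands highest of the three, and the larger swap gave a number 1.30 log units higher from compound 2 to compound 3 (beyond the scatter).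

Compound 4, `Cn1c(COc2cccc(C(=O)O)c2)nc2ccc(Oc3ncc(Cl)cc3F)cc21`, has not been measured. From compound 3 it differs by fluoro in place of chloro on an aromatic carbon. This is the same kind of change as from compound 1 to compound 2, not the same one: here the place is also meta to a chloro group. In this assay compound 4 is expected to give 1.4, with a likely range from 1 to 1.8. The expected step is a number 0.50 log units lower from compound 3 to compound 4 (beyond the scatter), a size chosen because a number 0.50 log units lower from compound 1 to compound 2 (beyond the scatter) came from the same swap.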

Compound 4, distribution coefficient: 1.3
Compound 4: middle estimate off by 0.10 log units, on the high side; low and high end bracket the measured number.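

In this assay, fluoro in place of chloro on the ring attached to the oxygen gave a number 0.60 log units lower from compound 3 to compound 4 (beyond the scatter), and the same kind of swap gave a number 0.50 log units lower from compound 1 to compound 2 (beyond the scatter), so both pairs moved in the same direction and both steps are beyond the scatter. Chloro in place of hydrogen also raised the number in both pairs, with a number 0.80 log units higher from compound 1 to compound 3 (beyond the scatter) and a number 0.70 log units higher from compound 2 to compound 4 (beyond the scatter), while the swap that changes two places at once gave a number 0.20 log units higher from compound 1 to compound 4 (within the scatter), a step within the scatter that separates neither compound from the other. Within the data shown here, these are only two matched pairs for each change, all on the shared core, so they do not show that the change would carry over to a different core, and nothing measured here explains the steps.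

Still open, as far as these compounds go, is whether fluoro in place of chloro would give a similar step if a methyl group or a nitrile replaced the chloro group in 5-chloro-3-fluoropyridin-2-yl. From the compounds shown here alone, it is also open whether that step would hold if an amide replaced the carboxylic acid elsewhere on the molecule.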